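The source may report more compounds than this note shows. Statements on the series, on what has been measured and on what is new or still open speak of the compounds shown alone.

Compound 1, `Cc1cc(-c2ccc(C#N)cc2)cc(Cl)c1Oc1ccnc(Nc2ccc(C#N)cc2)n1`, gives > 285000 nM.
Compound 2, `COc1cc(-c2ccc(C#N)cc2)ccc1Oc1ccnc(Nc2ccc(C#N)cc2)n1`, gives > 298000 nM.
Compound 3, `Cc1cc(-c2ccc(C#N)cc2F)ccc1Oc1ccnc(Nc2ccc(C#N)cc2)n1`, gives > 296000 nM.

All three were tested in a functional assay on MT4 cells (Homo sapiens) for cytotoxicity, read by MTT assay, with a stated time of 5 days; on this read-out lower numbers stand for higher toxicity in this test and higher numbers for lower toxicity in this test. For compound 1 the value of > 285000 nM is a limit of the assay rather than a number. For compound 2 the value of > 298000 nM is likewise a limit. For compound 3 the value of > 296000 nM is also a limit, so compound 3 stands where every compound shown stands: at a limit of this assay, with no number that would set it apart from the others. This is what (the limit of > 285000 nM in this assay, at which 1 of the 3 values shown sits), the limit of > 296000 nM in this assay, at which 1 of the 3 values shown sits, and the limit of > 298000 nM in this assay, at which 1 of the 3 values shown sits, record.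

Compound 4, `Cc1cc(-c2ccc(C#N)cc2)ccc1Oc1ccnc(Nc2ccc(C#N)cc2)n1`, has not yet been measured. It differs from compound 3 in one place: hydrogen in place of fluoro on an aromatic carbon, on an aromatic carbon of a six-membered aromatic ring of carbon only, ortho to a large group and meta to a cyano group. Among the compounds with values here, since every compound shown sits at a limit, no step between measured compounds can be drawn, and nothing in the data suggests that the change should bring the read-out into the measurable range. The step that the limit leaves unreadable from compound 3 to compound 4 is expected to be none beyond the scatter. Compound 4 is expected to give about 300000 nM in this assay, within 150000 nM to 600000 nM, and most likely to be reported once more as a limit.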

Compound 4, half-maximal cytotoxic concentration: > 310000 nM
Compound 4 ended at the assay's limit; the forecaster's own chance of this, stated with the estimate: 90%; middle value at least 1.0-fold (0.01 log units) from the limit.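

In this assay compound 4 gives > 310000 nM, which is a limit of the assay and not a number. Compound 1, compound 2 and compound 3 also stand at limits, so none of their steps to compound 4 can be read. The compounds shown leave open where their actual cytotoxic concentrations lie and whether any of these changes alters them.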